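Trifluoromethoxy in Place of Trifluoromethyl on a Silent Series

A few compounds are considered here, and "the series" means these few. Any claim that something is new, unique, unknown or untested is made for them only; others in the source may bear on it.

Compound 2 `Oc1cccc(-c2cc(-c3ccc(C(F)(F)F)cc3)cc(-c3ccccc3O)n2)c1` carries a 3-hydroxyphenyl and a 2-hydroxyphenyl on the shared core. In a functional assay on HeLa cells (Homo sapiens) for inhibition (on this read-out higher numbers stand for weaker inhibition and lower numbers for stronger inhibition), compound 2 gives only a limit, > 50000 nM. Compound 1 `Oc1ccccc1-c1cc(-c2ccc(C(F)(F)F)cc2)cc(-c2ccccc2O)n1` likewise sits at a limit in this assay, > 50000 nM. Compound 3 `Oc1ccc(-c2cc(-c3ccc(C(F)(F)F)cc3)cc(-c3ccccc3O)n2)cc1` also gives a limit, > 50000 nM. The steps among them, a step that the two limits leave unreadable from compound 1 to compound 2, a step that the two limits leave unreadable from compound 1 to compound 3 and a step that the two limits leave unreadable from compound 2 to compound 3, stay unreadable, as the limit of > 50000 nM in this assay, at which 3 of the 3 values shown sit, shows. Compound 4 `Oc1cccc(-c2cc(-c3ccc(OC(F)(F)F)cc3)cc(-c3ccccc3O)n2)c1` differs from compound 2 by trifluoromethoxy in place of trifluoromethyl on an aromatic carbon. Among the measured compounds shown here, no measured step bears on this change, and none of the measured compounds shows a number below the limit. Compound 4 is therefore expected to stay near that limit, the step of a number no higher from compound 2 to compound 4 (the limit leaves the size open) being an estimate only. The estimate for compound 4 in this assay is 50000 nM, within 15000 nM to 150000 nM.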

Compound 4, half-maximal inhibitory concentration: 20600 nM
Estimate against measurement, compound 4: 2.4-fold (0.39 log units) above, and the stated range covers the measured number.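

In this assay, trifluoromethoxy in place of trifluoromethyl on an aromatic carbon, para to a large group, gives an at least 2.4-fold lower number from compound 2 to compound 4 (0.38 log units; beyond the scatter). This position therefore responds to a change in a way that the shifts of the hydroxyl group among compounds 1, 2 and 3, whose steps cannot be read, could not show. Compound 4 is the only one of the four with a number, and the full size of its step remains open: the limit of > 50000 nM in this assay, at which 3 of the 4 values shown sit.

From the compounds shown here alone, whether the same change would act on the hydroxyphenyl arrangements of compound 1 and compound 3 remains open. So does the effect of an amine, a carboxylic acid or a longer chain at this position.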